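Chloro to Methoxy on Two Related Cores

A few compounds are considered here, and "the series" means these few. Any claim that something is new, unique, unknown or untested is made for them only; others in the source may bear on it.

Compound 1 `CC1CCN(C2CCN(S(=O)(=O)c3cccc(Cl)c3)CC2)CC1` and compound 2 `COc1cccc(S(=O)(=O)N2CCC(N3CCC(C)CC3)CC2)c1` share one core. In a functional assay on DLD-1 cells (Homo sapiens) for antiproliferative activity, read by CellTiter-Glo, with a stated time of 72 h (a higher number here means a weaker inhibitor, a lower number a stronger inhibitor), compound 1 gives only a limit, > 5000 nM. Compound 2 likewise gives only a limit in this assay, > 5000 nM. The change between them is methoxy in place of chloro on an aromatic carbon, and the step that the two limits leave unreadable from compound 1 to compound 2 cannot be read because both values sit at the limit of > 5000 nM in this assay, at which 2 of the 3 values shown sit. Compound 3 `CC1CCN(C2CCN(S(=O)(=O)c3ccccc3-c3ccc(Cl)cc3)CC2)CC1` is built on a different core; the difference between the two cores is not broken down here. In this assay compound 3 gives 202 nM. Compound 4 `COc1ccc(-c2ccccc2S(=O)(=O)N2CCC(N3CCC(C)CC3)CC2)cc1` carries the same kind of change, (methoxy in place of chloro on an aromatic carbon), though here the group sits para to a large group rather than meta to a large group. Within the data shown here, the one measured example of this change gives no readable size. The expected step is a 1.5-fold higher number from compound 3 to compound 4 (0.17 log units; within the scatter), resting on the value of compound 3, 202 nM. Compound 4 is estimated at 300 nM, between 100 nM and 1000 nM.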

Compound 4, half-maximal inhibitory concentration: 1000 nM
Compound 4: the middle estimate sits 3.3-fold (0.52 log units) below what was measured, within the range that was stated.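

On the core of compound 3, methoxy in place of chloro weakens the result in this assay, with a 5.0-fold higher number from compound 3 to compound 4 (0.69 log units; beyond the scatter) as the change is made. The same change on the core of compound 1 cannot be read, because compound 1 and compound 2 both sit at one limit: the limit of > 5000 nM in this assay, at which 2 of the 4 values shown sit. This single readable step shows a loss of activity on one core, but it does not show whether that loss carries over to another core, nor what causes it.

The compounds shown leave open how other groups in place of chloro, such as an amine or a carboxylic acid, would fare on the core of compound 3. They also leave open whether a step of this size would recur on a third core.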